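Fluoro for chloro on compound 2

The compounds below may be only part of what the source reports. "The series", "measured", "known", "first", "only" and "open" are said of these compounds alone.

In an in vitro ADME assay on microsomes from liver (Homo sapiens) for metabolic stability (on this read-out higher numbers stand for fast clearance and lower numbers for slow clearance), compound 1 (`O=C(COCc1ccccc1)N1CCN(c2ccc(F)cc2F)CC1`) gives 580 mL.min-1.g-1, and compound 2 (`O=C(COCc1ccncc1)N1CCN(c2ccc(Cl)cc2F)CC1`) gives 38 mL.min-1.g-1, the lower of the two numbers and beyond the scatter from compound 1. Compound 3 (`O=C(COCc1ccncc1)N1CCN(c2ccc(F)cc2F)CC1`) is next: fluoro in place of chloro on an aromatic carbon turns 4-chloro-2-fluorophenyl into 2,4-difluorophenyl (fluoro in place of chloro on an aromatic carbon). Going by the values given here, no measured pair shows this change alone, so the expectation is tentative. In this assay the expected change, a 1.3-fold lower number from compound 2 to compound 3 (0.10 log units; within the scatter), is none beyond the scatter. Compound 3 is expected at 30 mL.min-1.g-1, with an estimated range of 13 mL.min-1.g-1 to 75 mL.min-1.g-1.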

Compound 3, intrinsic clearance in microsomes: 22 mL.min-1.g-1
Estimate against measurement, compound 3: 1.4-fold (0.13 log units) above; measured number inside the range.
By their numbers in this assay, from the lowest: compounds 3 and 2 (each within the scatter of the next); then compound 1.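

Fluoro in place of chloro on this aromatic carbon, para to a large group, gives a 1.7-fold lower number from compound 2 to compound 3 (0.24 log units; within the scatter) in this assay, so the two halogens are not told apart here. Going by these compounds alone, the large step is the other one: pyridin-4-yl in place of phenyl, with the 2,4-difluorophenyl group held constant, gives a 26-fold lower number from compound 1 to compound 3 (1.42 log units; beyond the scatter) and is the first single-place reading of that swap. No measurement here bears on why either step arises.

From the compounds shown here alone, whether the halogen swap would read the same with phenyl in place of pyridin-4-yl remains open. So does the outcome of a nitrile or a methoxy group at this position.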